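The compounds below may be only part of what the source reports. "The series", "measured", "known", "first", "only" and "open" are said of these compounds alone.

Compound 1 `Cc1nnc(SCC(=O)c2ccc(Cl)cc2)n1N1C(=O)c2ccccc2C1=O` gives only a limit in a functional assay on HepG2 cells (Homo sapiens) for cytotoxicity, read by MTT assay, with a stated time of 48 h (a lower number here means a stronger inhibitor, a higher number a weaker inhibitor), namely > 200000 nM. Compound 2 `CCc1nnc(SCC(=O)c2ccc(Cl)cc2)n1N1C(=O)c2ccccc2C1=O` likewise gives only a limit, > 200000 nM. Compound 3 `COc1cc(-c2nnc(SCC(=O)c3ccc(Cl)cc3)n2N2C(=O)c3ccccc3C2=O)cc(OC)c1OC` gives a number, 22000 nM.

Among the measured compounds shown here, compound 3 is thus the one compound here with a measured number; the other two values sit at a limit of the assay (the limit of > 200000 nM in this assay, at which 2 of the 3 values shown sit). The two steps that lead to it, an at least 9.0-fold lower number from compound 1 to compound 3 (0.95 log units; beyond the scatter) and an at least 9.0-fold lower number from compound 2 to compound 3 (0.95 log units; beyond the scatter), both replace a small alkyl group on the shared core with 3,4,5-trimethoxyphenyl and both lower the number by at least a modest amount.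

Compound 4 `COc1ccc(C(=O)CSc2nnc(-c3cc(OC)c(OC)c(OC)c3)n2N2C(=O)c3ccccc3C2=O)cc1` differs from compound 3 in another part of the molecule: methoxy in place of chloro on an aromatic carbon. For the measured compounds named here, none of the measured steps touches this part; all three measured compounds keep the 4-chlorophenyl group unchanged, so nothing measured here speaks to a gain or a loss from this exchange. The step from compound 3 to compound 4 is therefore expected to stay within the scatter, a 1.1-fold higher number from compound 3 to compound 4 (0.06 log units; within the scatter). For compound 4 the estimate is 25000 nM, expected to lie between 8000 nM and 80000 nM.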

Compound 4, half-maximal inhibitory concentration: 28700 nM
Estimate against measurement, compound 4: 1.1-fold (0.06 log units) below; measured number inside the range.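

Among the compounds shown here, the 4-chlorophenyl group stayed unchanged in all the earlier compounds, so this pair gives the first reading at this position, on an aromatic carbon para to a large group. Methoxy in place of chloro gives a 1.3-fold higher number from compound 3 to compound 4 (0.12 log units; within the scatter) in this assay, so with 3,4,5-trimethoxyphenyl on the shared core, this exchange leaves the cytotoxicity reading unchanged within the usual scatter. The information available offers no explanation for this result.

From the compounds shown here alone, it remains open whether an amine, a carboxylic acid or a longer alkoxy chain at this position would shift the number beyond the scatter. Also open, going by these compounds, is whether methoxy in place of chloro would behave the same way on the cores of compound 1 and compound 2, which carry methyl and ethyl instead of 3,4,5-trimethoxyphenyl.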